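Adding Chloro to the Phenyl Ring of Compound 3

The source may report more compounds than this note shows. Statements on the series, on what has been measured and on what is new or still open speak of the compounds shown alone.

Compound 3 `CCCn1c(=O)[nH]c2nc(-c3ccc(S(=O)(=O)N4CCN(c5ccccc5)CC4)cc3)[nH]c2c1=O` carries a plain phenyl on the amine nitrogen of its ring. For the measured compounds named here, in an assay on CHO cells for displacement of a labelled ligand from adenosine receptor A2b (Homo sapiens), read by scintillation counting, with a stated time of 75 min, in the presence of a further agent that is not named here (a lower number here means a stronger inhibitor, a higher number a weaker inhibitor), compound 3 gives 0.643 nM, the second highest of the three numbers measured so far. Compound 1 `CCCn1c(=O)[nH]c2nc(-c3ccc(S(=O)(=O)N4CCN(c5cccc(Cl)c5)CC4)cc3)[nH]c2c1=O`, with a 3-chlorophenyl in that place, gives 0.342 nM, and the step of a 1.9-fold higher number from compound 1 to compound 3 (0.27 log units; within the scatter). Compound 2 `CCCn1c(=O)[nH]c2nc(-c3ccc(S(=O)(=O)N4CCN(c5ccccc5F)CC4)cc3)[nH]c2c1=O`, with a 2-fluorophenyl, gives 3.22 nM, and the step of a 5.0-fold lower number from compound 2 to compound 3 (0.70 log units; beyond the scatter).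

Compound 4 `CCCn1c(=O)[nH]c2nc(-c3ccc(S(=O)(=O)N4CCN(c5ccccc5Cl)CC4)cc3)[nH]c2c1=O` differs from compound 3 by chloro in place of hydrogen on an aromatic carbon; the chloro enters ortho to a large group, so the change reads phenyl to 2-chlorophenyl. Going by the values given here, two measured steps bear on it. The removal of the fluoro from compound 2 to give compound 3 was a modest step beyond the scatter, so a halogen in this position has once raised the number. The removal of the chloro from compound 1 to give compound 3 stayed within the scatter, but that chloro belonged to a 3-chlorophenyl, not a 2-chlorophenyl. Among the compounds with values here, no measured compound carries chloro where compound 4 does. The expected outcome is a modest rise in this assay, estimated as a 3.1-fold higher number from compound 3 to compound 4 (0.49 log units; beyond the scatter). Compound 4 is expected to give 2 nM, within a range of 0.5 nM to 8 nM.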

Compound 4, inhibition constant: 0.403 nM
For compound 4 the middle estimate is 5.0-fold (0.70 log units) above the measured one, and the stated range ends above it.
By their numbers in this assay, from the lowest: compounds 1, 4 and 3 (each within the scatter of the next); then compound 2.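

The step of a 1.6-fold lower number from compound 3 to compound 4 (0.20 log units; within the scatter) in this assay shows that chloro can enter on this aromatic carbon, ortho to a large group, with no change beyond the scatter, whereas fluoro in that place, in compound 2, went with a clearly higher number. Chloro and fluoro here do not read alike: the swap gives an 8.0-fold lower number from compound 2 to compound 4 (0.90 log units; beyond the scatter) and so the kind of halogen counts, not only its presence. The 2-chlorophenyl and 3-chlorophenyl groups, compared through a 1.2-fold higher number from compound 1 to compound 4 (0.07 log units; within the scatter) and so within the scatter, cannot be told apart in this assay and the plain phenyl of compound 3 also stays within the scatter of both.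

Nothing available explains why fluoro and chloro part ways at this place. Going by these compounds, whether a bromo, a methyl or a methoxy on this carbon would follow chloro or fluoro stays open, as does how a 3-fluorophenyl would compare with the 3-chlorophenyl of compound 1.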